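A few compounds are considered here, and "the series" means these few. Any claim that something is new, unique, unknown or untested is made for them only; others in the source may bear on it.

Measured in an ADME assay on NL20 cells (Homo sapiens) for antiproliferative activity, read by MTT assay, with a stated time of 24 h; on this read-out lower numbers stand for stronger inhibition and higher numbers for weaker inhibition:
- compound 1 `O=C(/C=C/c1ccc(O)cc1)NNC(=O)c1ccccc1`: 9750 nM
- compound 2 `COc1ccc(C(=O)NNC(=O)/C=C/c2ccc(O)cc2)cc1`: > 10000 nM (a limit of the assay, not a number)
- compound 3 `O=C(/C=C/c1ccc(O)cc1)NNC(=O)c1ccc(O)cc1`: 8620 nM

Compound 1 gives 9750 nM and sits within the scatter of compound 3, as shown by a 1.1-fold lower number from compound 1 to compound 3 (0.05 log units; within the scatter). Compound 2 is known only as a limit, > 10000 nM.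

The next compound is compound 4 `COc1cc(/C=C/C(=O)NNC(=O)c2ccccc2)ccc1O`, which carries one change from compound 1: methoxy in place of hydrogen on an aromatic carbon. The new methoxy is ortho to a hydroxy group and meta to a large group.

Within the data shown here, two measured steps bear on this change, although both act at a different place on the core of compound 1. Adding a methoxy there gives an at least 1.0-fold higher number from compound 1 to compound 2 (0.01 log units; that floor lies within the scatter), and this is only a floor because compound 2 sits at a limit. Adding a hydroxy there gives a 1.1-fold lower number from compound 1 to compound 3 (0.05 log units; within the scatter). Among the measured compounds shown here, neither step leaves the scatter, so the series so far offers no precedent for a real shift in this assay.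

The expected size is a 1.0-fold lower number from compound 1 to compound 4 (0.01 log units; within the scatter), which is no step beyond the scatter. With compound 1 so close to the limit of > 10000 nM in this assay, at which 1 of the 3 values shown sits, a reading at that limit is also expected to be quite possible. The estimate for compound 4 is 9500 nM, with an expected range from 5000 nM to 16000 nM.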

Compound 4, half-maximal inhibitory concentration: 9550 nM
Beside the measured number, compound 4's estimate is 1.0-fold (0.00 log units) below it, and the stated range covers the measured number.
By their numbers in this assay, from the lowest: compounds 3, 4 and 1 (each within the scatter of the next). At a limit, above all of these: compound 2.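

In this assay, methoxy in place of hydrogen at this position, ortho to a hydroxy group and meta to a large group, gives a 1.0-fold lower number from compound 1 to compound 4 (0.01 log units; within the scatter). Unlike the step to compound 2, which is only a floor, this step is a full reading, so the series now holds a measured number for a methoxy added to the core of compound 1, and that number shows no shift beyond the scatter. The reading remains close to the top of the readable range, so a modest loss at this position could appear only as a limit rather than as a number: the limit of > 10000 nM in this assay, at which 1 of the 4 values shown sits.

Going by these compounds, whether another group at this position, such as an amine, a carboxylic acid or a longer chain, would move the number beyond the scatter remains open. Also open, on these data alone, is whether methoxy here would make a measurable difference on a close relative of compound 1 that reads well clear of the limit, since all the readable values lie within the scatter of one another.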